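The source may report more compounds than this note shows. Statements on the series, on what has been measured and on what is new or still open speak of the compounds shown alone.

Measured compounds in a functional assay on P388 cells (Mus musculus) for cytotoxicity; on this read-out higher numbers stand for weaker inhibition and lower numbers for stronger inhibition:
compound 1 `COc1ccc(C[C@H]2C(=O)N[C@@H](C)C(=O)N(C)[C@H]3Cc4ccc(cc4)Oc4cc(ccc4OC)C[C@@H](C(=O)N[C@H](C)C(=O)N[C@@H](CO)C(=O)N2C)N(C)C3=O)cc1` gives 14.1 nM
compound 2 `COc1ccc(C[C@H]2C(=O)N[C@@H](C)C(=O)N(C)[C@H]3Cc4ccc(cc4)Oc4cc(ccc4OC)C[C@@H](C(=O)N[C@H](C)C(=O)N[C@@H](CCCCO)C(=O)N2C)N(C)C3=O)cc1` gives 219 nM

For the measured compounds named here, compound 1 stands lowest of the two numbers in this assay; the only other measured compound, compound 2, lies at a 16-fold higher number from compound 1 to compound 2 (1.19 log units; beyond the scatter). The unmeasured compound 3 `COc1ccc(C[C@H]2C(=O)N[C@@H](C)C(=O)N(C)[C@H]3Cc4ccc(cc4)Oc4cc(ccc4OC)C[C@@H](C(=O)N[C@H](C)C(=O)N[C@@H](CCSC)C(=O)N2C)N(C)C3=O)cc1` differs from compound 1 by (methylsulfanyl)methyl in place of hydroxy on a saturated chain carbon bound to a saturated ring carbon. Going by the values given here, the single step that bears on this is the one from compound 1 to compound 2, where the hydroxy was extended and the number rose by a large amount, beyond the scatter. A longer group at the same place is therefore expected to weaken inhibition in this assay, likely by less than that step. For compound 3 the expected value is 60 nM (range 15 nM to 250 nM), an estimated step of a 4.3-fold higher number from compound 1 to compound 3 (0.63 log units; beyond the scatter).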

Compound 3, half-maximal inhibitory concentration: 20.4 nM
Compound 3: middle estimate off by 2.9-fold (0.47 log units), on the high side, and the stated range covers the measured number.
By their numbers in this assay, from the lowest: compounds 1 and 3 (each within the scatter of the next); then compound 2.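

In this assay, a longer group at this position does not by itself cost activity: a 1.4-fold higher number from compound 1 to compound 3 (0.16 log units; within the scatter), so the hydroxy of compound 1 can be replaced here with no change beyond the scatter. The large step seen with compound 2 is therefore not general to longer groups, and compound 3 goes against that reading, with an 11-fold lower number from compound 2 to compound 3 (1.03 log units; beyond the scatter). Nothing available accounts for the difference between these two groups.

Open, as far as these compounds go, is how an amine or a carboxylic acid would read in place of that hydroxy. Also open, from the compounds shown here alone, is whether a plain butyl chain follows compound 2 or compound 3.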